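Swapping the thiocarbonyl ring of compound 1 for pyrrolidine

The compounds below may be only part of what the source reports. "The series", "measured", "known", "first", "only" and "open" are said of these compounds alone.

Compound 1 `Cc1ccnc(/C(N)=N/NC(=S)N2CCSCC2)c1` was tested in a functional assay on A-375 cells (Homo sapiens) for cytotoxicity, read by MTT assay, with a stated time of 72 h, tested at 1 uM (a higher number here means more inhibition of growth at the concentration tested, a lower number less inhibition of growth), where compound 1 gives 47.7%. Two near relatives were measured alongside it. Among the compounds with values here, compound 2 `N/C(=N\NC(=S)N1CCSCC1)c1ccccn1` gives 34% in this assay, and the step of a number 13.7 percentage points lower from compound 1 to compound 2 (beyond the scatter) is the only single-point comparison available. Within the data shown here, compound 3 `N/C(=N\NC(=S)N1CCOCC1)c1ccc(F)cn1` gives 44.5% in this assay; it differs from compound 1 in more than one place, so no single step can be drawn, and its number sits within the usual scatter of that of compound 1. Of the three numbers shown, that of compound 1 is the largest, with compound 3 close to it and compound 2 the furthest away.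

Compound 4 `Cc1ccnc(/C(N)=N/NC(=S)N2CCCC2)c1` is the next compound, and it differs from compound 1 by pyrrolidin-1-yl in place of thiomorpholin-4-yl on a thiocarbonyl carbon. Among the measured compounds shown here, none of the measured steps touches this part of the molecule: the only step seen concerns the methyl on the aromatic ring, and compound 3 changes both the ring on the thiocarbonyl carbon and the aromatic part at once. There is therefore no direct guide, and the step of a number 3.7 percentage points lower from compound 1 to compound 4 (within the scatter) is expected to stay within the scatter, in either direction. Compound 4 is estimated to give about 44% in this assay, with a range from 28% to 60%.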

Compound 4, percent growth inhibition at one concentration: 69%
Estimate against measurement, compound 4: 25 percentage points below, outside the stated range (above it).
By their numbers in this assay, from the lowest: compound 2; then compounds 3 and 1 (each within the scatter of the next); then compound 4.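

In this assay, the group on the thiocarbonyl carbon turns out to be a place where a single change moves the number clearly: pyrrolidin-1-yl in place of thiomorpholin-4-yl gives a number 21.3 percentage points higher from compound 1 to compound 4 (beyond the scatter). Within the data shown here, this is the first change in one place that raises the number, since the only earlier such step, which concerned the methyl on the aromatic ring, lowered it, and it shows that the thiomorpholin-4-yl group of compound 1 can be replaced by a smaller ring with one hetero atom and no sulfur without any loss in growth inhibition at the concentration tested. The data at hand offer nothing that accounts for this rise.

Going by these compounds, the step changes ring size and removes the sulfur together, so it remains open which of the two goes with the higher number, and a piperidin-1-yl group on the same carbon of the core of compound 1 would separate them. Also open, on these data alone, are whether an open-chain dimethylamino group serves as well as the ring, and whether pyrrolidin-1-yl gives a similar step on the core of compound 2, which lacks the methyl.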